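The source may report more compounds than this note shows. Statements on the series, on what has been measured and on what is new or still open speak of the compounds shown alone.

Measured so far in an ADME assay on cells (Hepatocyte, Mus musculus) for cytotoxicity, read by MTT assay, with a stated time of 24 h; a higher number here means that more compound is tolerated, a lower number that less compound is tolerated:

- compound 1 (`O=S(=O)(c1ccc(F)cc1)n1c(-c2cn(-c3ccccc3)nc2-c2ccc(F)cc2)nc2ccccc21`) gives 174000 nM
- compound 2 (`O=S(=O)(c1ccc(Cl)cc1)n1c(-c2cn(-c3ccccc3)nc2-c2ccc(F)cc2)nc2ccccc21`) gives 231000 nM

Compound 2 stands level with compound 1, as their two values lie within the usual scatter of each other. Compound 3 (`O=S(=O)(c1ccc(Cl)cc1)n1c(-c2cn(-c3ccccc3)nc2-c2ccc(C(F)(F)F)cc2)nc2ccccc21`) departs from compound 2 in one place, where a 4-fluorophenyl becomes a 4-(trifluoromethyl)phenyl (trifluoromethyl in place of fluoro on an aromatic carbon). Among the measured compounds shown here, only one measured step bears on this, and only loosely, since it is a chloro in place of a fluoro at a different place in the molecule. That step was small (a 1.3-fold higher number from compound 1 to compound 2 (0.12 log units; within the scatter)) and stayed inside the scatter. Trifluoromethyl itself has no measured precedent among these compounds, so the guide is thin, but no change beyond the scatter is expected in this assay here. The estimated step is small (a 1.2-fold lower number from compound 2 to compound 3 (0.06 log units; within the scatter)). For compound 3 the expected value is 200000 nM (estimated range 100000 nM to 400000 nM).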

Compound 3, half-maximal cytotoxic concentration: 173000 nM
Estimate against measurement, compound 3: 1.2-fold (0.06 log units) above; measured number inside the range.
By their numbers in this assay, from the lowest: compounds 3, 1 and 2 (each within the scatter of the next).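

Putting trifluoromethyl in place of fluoro on an aromatic carbon, para to a large group, gives a 1.3-fold lower number from compound 2 to compound 3 (0.13 log units; within the scatter) in this assay. Among the compounds shown here, the earlier step changed a different place in the molecule, so this is the first look at this position, and here four heavy atoms replace one with no change that can be told from the scatter. Nothing measured here speaks to a cause for this result.

As far as these compounds go, all three compounds carry fluorine at this position, so it stays open whether a group of another kind there, such as an amine or a carboxylic acid, would also stay within the scatter. From the compounds shown here alone, a longer chain at the same place is equally open, and so is whether it would move the number in this assay at all.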